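Swapping a bicyclic aromatic onto the shared core

The compounds below may be only part of what the source reports. "The series", "measured", "known", "first", "only" and "open" are said of these compounds alone.

Among the measured compounds shown here, compound 1 `COc1ccc(-c2nnc(CCSC(=S)NCc3cccnc3)o2)cc1` is one of two compounds measured in a functional assay on Bel-7402 cells (Homo sapiens) for cytotoxicity, read by resazurin assay, with a stated time of 72 h; a lower number here means a stronger inhibitor, a higher number a weaker inhibitor; there compound 1 gives 1540 nM, the lower of the two numbers. Compound 2 `S=C(NCc1cccnc1)SCCc1nnc(-c2ccc3ccccc3n2)o1` gives 1950 nM in this assay, which lies within the usual scatter of the value of compound 1, so the two cannot be ordered. Compound 3 `S=C(NCc1cccnc1)SCCc1nnc(-c2cc3ccccc3s2)o1` differs from compound 1 by 1-benzothiophen-2-yl in place of 4-methoxyphenyl on an aromatic carbon. For the measured compounds named here, with no measured step of this kind to draw on, and compound 2 showing that another bicyclic aromatic at this place gives a similar number, compound 3 is expected to change little: a step of a 1.2-fold higher number from compound 1 to compound 3 (0.07 log units; within the scatter), not beyond the scatter. Compound 3 is estimated at 1800 nM, between 700 nM and 4500 nM.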

Compound 3, half-maximal inhibitory concentration: 6890 nM
Compound 3: middle estimate off by 3.8-fold (0.58 log units), on the low side; the measured number lies above the stated range.
By their numbers in this assay, from the lowest: compounds 1 and 2 (each within the scatter of the next); then compound 3.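

In this assay, among the compounds shown here, this position proves sensitive to the group it carries: 1-benzothiophen-2-yl in place of 4-methoxyphenyl gives a 4.5-fold higher number from compound 1 to compound 3 (0.65 log units; beyond the scatter), a step the earlier compounds did not reveal. Carrying a bicyclic aromatic here does not by itself keep the number, as compound 2 gives 1950 nM and compound 3 gives 6890 nM in this comparison. Nothing available here accounts for the step. As far as these compounds go, what an amine or a carboxylic acid at this place would give stays open. The compounds shown also do not separate the sulfur of the entering group from its five-membered ring.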